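This account rests on a few compounds, and the source may have more. Where it says the series, first, only, none or still open, it means among the compounds named here.

Compound 1 `O=C(CCCCC(S)CCS)Nc1ccccc1` gives 6.38%
Compound 2 `O=C(CCCCC(S)CCS)Nc1cccc(Cl)c1` gives "not active" (no number reported)

Both compounds were tested in a functional assay on HO8910 cells (Homo sapiens) for inhibition, read by MTT assay, with a stated time of 24 h, tested at 1 ug/mL; on this read-out higher numbers stand for more inhibition of growth at the one concentration tested and lower numbers for less inhibition of growth. Compound 2 has no single number on this read-out: it is reported as "not active" (no number reported). Compound 1 gives 6.38%, and no numerical gap between the two can be stated.

Compound 3 `O=C(CCCCC(S)CCS)Nc1cccc(C(F)(F)F)c1` keeps the shared core and differs from compound 2 at one place, with trifluoromethyl in place of chloro on an aromatic carbon. Going by the values given here, no measured step is available to size this change. In this assay the expected step is therefore none beyond the usual scatter, with no direction favoured. This expectation rests on the two existing results: compound 1 gives only 6.38%, and compound 2 is reported as "not active" (no number reported). Compound 3 may likewise be reported without a number. If a number is reported, the estimate for compound 3 is an expected 5%, within an expected range of 0% to 15%.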

Compound 3, percent growth inhibition at one concentration: 13.7%
Compound 3: middle estimate off by 8.7 percentage points, on the low side; the range from low to high includes it.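

In this assay, trifluoromethyl on this aromatic carbon yields a reported number where chloro at the same place does not: compound 2 is recorded as "not active" (no number reported) and compound 3 gives 13.7%, so the step between these two cannot be read. The comparison that can be read is with the unsubstituted compound, where trifluoromethyl in place of hydrogen gives a number 7.3 percentage points higher from compound 1 to compound 3 (within the scatter), so exchanging hydrogen for this larger group, with four heavy atoms, has no effect here that can be told from the scatter of the read-out at the one concentration tested. Nothing measured on these compounds accounts for the contrast between chloro and trifluoromethyl.

The compounds shown leave open whether an amine or a methoxy group on this same aromatic carbon would give a value clearly apart from those of compound 1 and compound 3. They also leave open whether a longer chain in place of the one on the shared core would move the reading beyond the scatter.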